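Replacing a Side Group With Furan-2-yl in Compound 1

The source may report more compounds than this note shows. Statements on the series, on what has been measured and on what is new or still open speak of the compounds shown alone.

Going by the values given here, in a functional assay on KB cells (Homo sapiens) for cytotoxicity (a lower number here means a stronger inhibitor, a higher number a weaker inhibitor), compound 1 (`C/C=C/C(=O)OC1=CC(=O)c2ccccc2C1=O`) gives 64200 nM and so has the highest number of the three measured so far, beyond the scatter from both others. Compound 2 (`Cc1ccc(S(=O)(=O)Oc2ccc3c(c2)C(=O)C=CC3=O)cc1`) at 16400 nM and compound 3 (`O=C1C=CC(=O)c2c(Oc3ccco3)cccc21`) at 13400 nM both sit lower. Unmeasured compound 4 (`O=C1C=C(Oc2ccco2)C(=O)c2ccccc21`) differs from compound 1 by one change (furan-2-yl in place of (prop-1-en-1-yl)carbonyl on an oxygen on an unsaturated carbon) with furan-2-yl in place of (prop-1-en-1-yl)carbonyl on an oxygen on an unsaturated carbon. Among the compounds with values here, no measured pair shows this change. Compound 3 also carries furan-2-yl and gives 13400 nM so a drop in this assay beyond the scatter is expected. The estimated step is a 4.3-fold lower number from compound 1 to compound 4 (0.63 log units; beyond the scatter) toward a lower number. For compound 4 an estimate of 15000 nM is expected, with 5000 nM and 40000 nM as the ends of its range.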

Compound 4, half-maximal inhibitory concentration: 53400 nM
Compound 4: middle estimate off by 3.6-fold (0.55 log units), on the low side; the measured number lies above the stated range.
By their numbers in this assay, from the lowest: compounds 3 and 2 (each within the scatter of the next); then compounds 4 and 1 (each within the scatter of the next).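

In this assay, putting furan-2-yl in place of (prop-1-en-1-yl)carbonyl on this oxygen gives a 1.2-fold lower number from compound 1 to compound 4 (0.08 log units; within the scatter). At this position, then, an open chain and a five-membered aromatic ring of the same heavy-atom count cannot be told apart, and furan-2-yl alone brings no real change. No measurement here accounts for this result.

Going by these compounds, whether an amine, a carboxylic acid or a longer chain on this oxygen would move the number remains open. So does whether this swap would behave the same way on a different core.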